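The source may hold more compounds than are shown below. What is called first, only, known or untested is meant among the compounds shown, and "the series" means these compounds.

Compound 1, with the structure `N#Cc1ccc(OCc2ccsc2)cc1OC(C(=O)O)c1ccccc1Br`, is one of three compounds tested in an assay on A10 cells for antagonist activity at Endothelin-1 receptor (Rattus norvegicus) (a higher number here means a weaker inhibitor, a lower number a stronger inhibitor), where it gives 51 nM, the lowest of the three numbers. Compound 2, `N#Cc1ccc(OCc2ccsc2)cc1OC(C(=O)O)c1ccccc1C(F)(F)F`, gives 53 nM, and the step of a 1.0-fold higher number from compound 1 to compound 2 (0.02 log units; within the scatter) shows no real separation between the two. Compound 3, `N#Cc1ccc(OCc2ccsc2)cc1OC(C(=O)O)c1ccco1`, gives 2400 nM, a much higher number, as the step of a 47-fold higher number from compound 1 to compound 3 (1.67 log units; beyond the scatter) records.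

Compound 4, `N#Cc1ccc(OCc2ccsc2)cc1OC(C(=O)O)c1ccsc1`, is the next compound for this assay. Compared with compound 1 the change is thiophen-3-yl in place of 2-bromophenyl on a saturated chain carbon bound to a carbonyl carbon and an oxygen on an aromatic ring. Going by the values given here, the steps that bear on this are a 47-fold higher number from compound 1 to compound 3 (1.67 log units; beyond the scatter) and a 45-fold higher number from compound 2 to compound 3 (1.66 log units; beyond the scatter), both large, and both of them also exchange a six-membered carbon ring on the same saturated chain carbon for a five-membered aromatic ring with one hetero atom. A step of similar size and in the same direction is therefore expected here, a 29-fold higher number from compound 1 to compound 4 (1.47 log units; beyond the scatter). For compound 4 the estimate is 1500 nM, within a range from 400 nM to 5000 nM.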

Compound 4, half-maximal inhibitory concentration: 630 nM
Compound 4: middle estimate off by 2.4-fold (0.38 log units), on the high side, and the stated range covers the measured number.
By their numbers in this assay, from the lowest: compounds 1 and 2 (each within the scatter of the next); then compound 4; then compound 3.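

In this assay, thiophen-3-yl at this saturated chain carbon also falls well short of both substituted phenyl groups, with a 12-fold higher number from compound 1 to compound 4 (1.09 log units; beyond the scatter) and a 12-fold higher number from compound 2 to compound 4 (1.08 log units; beyond the scatter), so the large rise seen with furan-2-yl is not confined to that one five-membered ring. The two five-membered rings are not equivalent, however, as a 3.8-fold lower number from compound 3 to compound 4 (0.58 log units; beyond the scatter) shows, meaning that the size of the loss depends on which ring enters. Nothing available explains these differences.

Furan-2-yl and thiophen-3-yl differ in both the hetero atom and the ring position of attachment, and a thiophen-2-yl or furan-3-yl group would be needed to separate those two changes. Going by these compounds, it also remains open how a plain phenyl group would compare with the bromo and trifluoromethyl phenyl groups, and whether a six-membered pyridine ring would keep their low numbers.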